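A few compounds are considered here, and "the series" means these few. Any claim that something is new, unique, unknown or untested is made for them only; others in the source may bear on it.

Measured so far:
- compound 1 `Cn1nc(C(F)(F)F)cc1C(=O)Nc1ccc(S(=O)(=O)N2CCCCCC2)cc1`: > 300000 nM
- compound 2 `Cn1nc(C(F)(F)F)cc1C(=O)Nc1ccc(S(=O)(=O)N2CCCCCCC2)cc1`: 16000 nM

In an ADME assay on Vero cells (Chlorocebus sabaeus) for cytotoxicity, read by MTT assay (on this read-out lower numbers stand for higher toxicity in this test and higher numbers for lower toxicity in this test), compound 1 gives only a limit, not a number (the limit of > 300000 nM in this assay, at which 1 of the 2 values shown sits); it stands at the least toxic end of the two values shown. For the measured compounds named here, the one measured step, an at least 18-fold lower number from compound 1 to compound 2 (1.27 log units; beyond the scatter), concerns ring size alone. Compound 3 `Cn1nc(C(F)(F)F)cc1C(=O)Nc1ccc(S(=O)(=O)N2CCCCC2C(=O)O)cc1` differs from compound 1 by 2-carboxypiperidin-1-yl in place of azepan-1-yl on a sulfonyl sulfur. Going by the values given here, no measured step covers a carboxylic acid, so that change offers no direct guide, and the ring-size step runs toward a smaller ring here. The expectation is a step of about an at least 1.2-fold lower number from compound 1 to compound 3 (0.07 log units; that floor lies within the scatter), within or near the scatter. Compound 3 is estimated at 250000 nM, with a range from 60000 nM to 300000 nM.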

Compound 3, half-maximal cytotoxic concentration: > 300000 nM
Compound 3 was reported as a limit; the forecaster's own chance of this, stated with the estimate: 55%; at least 1.2-fold (0.07 log units) between middle value and limit.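

In this assay compound 3 is reported only as a limit, and the step involving the two limits cannot be read. On the sulfonyl sulfur, 2-carboxypiperidin-1-yl gives an at least 18-fold higher number from compound 2 to compound 3 (1.27 log units; beyond the scatter), so a ring carrying a carboxylic acid also sits far from the eight-membered ring on this read-out. Two different groups at this position now reach the same limit: the limit of > 300000 nM in this assay, at which 2 of the 3 values shown sit.

As far as these compounds go, how far either limit lies from a true value stays open. So does the separate share of ring size and carboxylic acid, which piperidin-1-yl without the acid, or a methyl ester in its place, would address.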